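From Methyl to Tert-Butyl on the Aromatic Carbon

This account rests on a few compounds, and the source may have more. Where it says the series, first, only, none or still open, it means among the compounds named here.

Compound 1 `COc1cc(N(Cc2nc3ccccc3[nH]2)C(=O)c2ccccc2)cc(OC)c1OC` is the parent of the set. In a functional assay on MGC-803 cells (Homo sapiens) for inhibition, read by MTT assay, with a stated time of 48 h (a higher number here means a weaker inhibitor, a lower number a stronger inhibitor), compound 1 gives only a limit, > 50000 nM, as the limit of > 50000 nM in this assay, at which 1 of the 2 values shown sits, records. Compound 2 `COc1cc(N(Cc2nc3ccccc3[nH]2)C(=O)c2ccc(C)cc2)cc(OC)c1OC` carries a methyl in place of hydrogen on an aromatic carbon, and in this assay compound 2 gives 30500 nM, the only number shown among the two values. The step of an at least 1.6-fold lower number from compound 1 to compound 2 (0.21 log units; that floor lies within the scatter) is all that the measured pair offers. Compound 3 `COc1cc(N(Cc2nc3ccccc3[nH]2)C(=O)c2ccc(C(C)(C)C)cc2)cc(OC)c1OC` differs from compound 2 by tert-butyl in place of methyl on an aromatic carbon, a tert-butyl in place of methyl on an aromatic carbon, para to a large group. Among the compounds with values here, only the step from compound 1 to compound 2 bears on this change, and its floor sits within the scatter, so no step beyond the scatter is firmly expected, though whatever direction there is points to a lower number. Compound 3 is therefore expected to give about 20000 nM, between 8000 nM and 50000 nM. The expected step is a 1.5-fold lower number from compound 2 to compound 3 (0.18 log units; within the scatter).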

Compound 3, half-maximal inhibitory concentration: > 50000 nM
Compound 3 gave a limit, no number; the forecaster's own chance of this, stated with the estimate: 25%; middle value at least 2.5-fold (0.39 log units) away from the limit.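

On this aromatic carbon, para to a large group, the larger tert-butyl brings no readable gain in inhibition: in this assay the change from 4-methylphenyl to 4-(tert-butyl)phenyl gives an at least 1.6-fold higher number from compound 2 to compound 3 (0.21 log units; that floor lies within the scatter) and that floor does not settle the size of the change. Compound 3 gives only a limit, > 50000 nM and not a number. The step from compound 1 to compound 3 cannot be read, and compound 2 remains the only compound of the three with a number, while the other two share one limit: the limit of > 50000 nM in this assay, at which 2 of the 3 values shown sit.

From the compounds shown here alone, how far compound 3 truly lies from compound 2 stays open. So does whether ethyl or isopropyl, or an amine or a carboxylic acid, on this carbon would give a number in this assay at all.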